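This account rests on a few compounds, and the source may have more. Where it says the series, first, only, none or still open, it means among the compounds named here.

In an ADME assay on L929 cells (Mus musculus) for cytotoxicity, read by resazurin assay, with a stated time of 72 h (a lower number here means a stronger inhibitor, a higher number a weaker inhibitor), compound 1 `O=C(/C=C/c1ccc2c(c1)B(O)OC2)c1ccco1` reads only as a limit, > 10 ug/mL. Compound 3 `O=C(/C=C/c1ccc2c(c1)B(O)OC2)c1ccc(F)cc1` is likewise a limit, > 10 ug/mL. Compound 2 `Cc1cccc(C(=O)/C=C/c2ccc3c(c2)B(O)OC3)c1` alone gives a number, 8.56 ug/mL. Compound 4 `O=C(/C=C/c1ccc2c(c1)B(O)OC2)c1ccc(-c2ccccc2)cc1` differs from compound 3 by phenyl in place of fluoro on an aromatic carbon, with phenyl in place of fluoro on an aromatic carbon. For the measured compounds named here, no measured step makes this exact change, but three steps alter the group on the carbonyl carbon. These are an at least 1.1-fold lower number from compound 1 to compound 2 (0.06 log units; that floor lies within the scatter), an at least 1.1-fold higher number from compound 2 to compound 3 (0.06 log units; that floor lies within the scatter), and a step that the two limits leave unreadable from compound 1 to compound 3. From the compounds shown here alone, each readable step is known only as a floor, so the size of the change remains open. A modest move towards the number of compound 2 is expected, since compound 2 reads 8.56 ug/mL. The expected result is an at least 1.2-fold lower number from compound 3 to compound 4 (0.09 log units; that floor lies within the scatter). For compound 4, the estimated value is 8 ug/mL, with an expected range of 3 ug/mL to 20 ug/mL.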

Compound 4, half-maximal inhibitory concentration: > 10 ug/mL
Compound 4 ended at the assay's limit; the forecaster's own chance of this, stated with the estimate: 50%; middle value at least 1.2-fold (0.09 log units) away from the limit.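

Compound 3 and compound 4 both read only as limits in this assay, so the step between them cannot be read, because both sit at the same limit: the limit of > 10 ug/mL in this assay, at which 3 of the 4 values shown sit. The compounds shown leave open where the actual values of compound 1, compound 3 and compound 4 lie.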